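The source may report more compounds than this note shows. Statements on the series, on what has been measured and on what is new or still open speak of the compounds shown alone.

Measured so far:
Compound 1 `CCOc1ccccc1-n1nncc1CN1C(=O)C2(C(C#N)=C(N)Oc3c(N)cc4nc5ccccc5nc4c32)c2ccccc21` — in a functional assay on MCF7 cells (Homo sapiens) for antiproliferative activity, read by MTT assay, with a stated time of 48 h (on this read-out lower numbers stand for stronger inhibition and higher numbers for weaker inhibition), compound 1 gives > 50000 nM, which is a limit of the assay and not a number.
Compound 2 `N#CC1=C(N)Oc2c(N)cc3nc4ccccc4nc3c2C12C(=O)N(Cc1cnnn1-c1ccc(F)c(Cl)c1)c1ccccc12` — in this assay compound 2 gives 17800 nM.

Compound 2 therefore stands with the only number shown in this assay; the other value is a limit. Among the compounds with values here, the single measured step leads to it: an at least 2.8-fold lower number from compound 1 to compound 2 (0.44 log units; beyond the scatter). Its size can only be given as a lower bound because of the limit of > 50000 nM in this assay, at which 1 of the 2 values shown sits.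

Compound 3 `N#CC1=C(N)Oc2c(N)cc3nc4ccccc4nc3c2C12C(=O)N(Cc1cnnn1-c1c(Cl)cc(Cl)cc1Cl)c1ccccc12` differs from compound 2 at the same aromatic nitrogen: 2,4,6-trichlorophenyl in place of 3-chloro-4-fluorophenyl on an aromatic nitrogen. Within the data shown here, the one measured step that bears on this change swaps one aryl group for another at that nitrogen and was at least modest in size, but it starts from a limit, so it fixes only a direction and a floor, not a scale. A second halogenated aryl at the same place gives no basis for expecting a step beyond the scatter in either direction, so the estimated step is a 1.2-fold lower number from compound 2 to compound 3 (0.07 log units; within the scatter). Compound 3 is thus expected to give about 15000 nM in this assay, with a range from 5000 nM to 45000 nM.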

Compound 3, half-maximal inhibitory concentration: 37800 nM
Beside the measured number, compound 3's estimate is 2.5-fold (0.40 log units) below it; low and high end bracket the measured number.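

At this aromatic nitrogen, the choice between two halogen-bearing phenyl groups changes the read-out in this assay: putting 2,4,6-trichlorophenyl in place of 3-chloro-4-fluorophenyl gives a 2.1-fold higher number from compound 2 to compound 3 (0.33 log units; beyond the scatter). This is the first step at this position with a number at both ends, so it gives a true size and not only a direction, and it leaves compound 2 as the strongest of the compounds shown. Replacing 2-ethoxyphenyl with 2,4,6-trichlorophenyl gives an at least 1.3-fold lower number from compound 1 to compound 3 (0.12 log units; that floor lies within the scatter), so the gap between these two groups is known only as a floor, and compound 1 and compound 3 cannot be firmly ordered on that basis: the limit of > 50000 nM in this assay, at which 1 of the 3 values shown sits.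

The step from compound 2 to compound 3 changes the number of chlorine atoms, removes the fluorine and moves the substituents around the phenyl ring all at once, so the compounds shown cannot say which of these changes matters. They also leave open how an unsubstituted phenyl, a phenyl bearing an amine or a carboxylic acid, or a simple alkyl chain on the same nitrogen would compare with the 3-chloro-4-fluorophenyl group of compound 2.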